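A few compounds are considered here, and "the series" means these few. Any claim that something is new, unique, unknown or untested is made for them only; others in the source may bear on it.

Compound 1 `O=C1N[C@H]2[C@H](CS[C@H]2CCCCCc2cn(Cc3ccccc3O)nn2)N1`: > 16000 nM
Compound 2 `O=C1N[C@H]2[C@H](CS[C@H]2CCCCCc2cn(Cc3ccccc3Cl)nn2)N1`: > 16000 nM

In an assay on isolated protein for inhibition of biotin--protein ligase (Homo sapiens), read by scintillation counting, with a stated time of 10 min (on this read-out lower numbers stand for stronger inhibition and higher numbers for weaker inhibition), compound 1 gives > 16000 nM, which is a limit of the assay rather than a number. Compound 2 gives > 16000 nM in this assay, also a limit. For the measured compounds named here, the one measured step, a step that the two limits leave unreadable from compound 1 to compound 2, cannot be read because of the limit of > 16000 nM in this assay, at which 2 of the 2 values shown sit. Compound 3 `O=C1N[C@H]2[C@H](CS[C@H]2CCCCCc2cn(Cc3cccc(Cl)c3)nn2)N1` carries 3-chlorophenyl in place of 2-chlorophenyl on a saturated chain carbon bound to an aromatic nitrogen. Going by the values given here, no measured step bears on this change, so nothing suggests a shift beyond the scatter. Compound 3 is therefore expected to stay near the limit, at an estimated 20000 nM within 8000 nM to 50000 nM, an expected step that the limit leaves unreadable from compound 2 to compound 3.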

Compound 3, inhibition constant: > 16000 nM
Compound 3: no number, only a limit; the forecaster's own chance of this, stated with the estimate: 70%; the middle value lies beyond the limit too.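

For the compounds shown here, no step between compound 1, compound 2 and compound 3 can be read, because each gives a limit of the assay rather than a number: the limit of > 16000 nM in this assay, at which 3 of the 3 values shown sit. On these data alone, whether these group changes alter inhibition at all stays open.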